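Oxan-4-yl in Place of Cyclohexyl: An Expected Outcome

A few compounds are considered here, and "the series" means these few. Any claim that something is new, unique, unknown or untested is made for them only; others in the source may bear on it.

Three compounds have been measured in an assay on HEK293 cells for activation of Kir3.1/Kir3.2 (Homo sapiens), read by thallium flux; on this read-out higher numbers stand for an effect only at larger amounts of compound and lower numbers for an effect already at smaller amounts:

compound 1 `O=C(Cn1nnc(-c2ccccc2)n1)NC1CC2CCC1C2`: 1980 nM
compound 2 `Cc1cc(NC(=O)Cn2nnc(-c3ccccc3)n2)n(C2CCCCC2)n1`: 96 nM
compound 3 `Cc1cc(NC(=S)Cn2nnc(-c3ccccc3)n2)n(C2CCCCC2)n1`: 623 nM

Compound 2 stands lowest of the three numbers in this assay. Its nearest neighbour is compound 3, whose number is higher by more than the scatter, and the furthest is compound 1, whose number is higher still, also beyond the scatter. No pair among these measured compounds has been set out as a single-point step, so their values can only be read side by side.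

Compound 4 `Cc1cc(NC(=O)Cn2nnc(-c3ccccc3)n2)n(C2CCOCC2)n1` is the next compound to be measured. It differs from compound 2 in one place: oxan-4-yl in place of cyclohexyl on an aromatic nitrogen. Going by the values given here, nothing among the measured compounds shows what this particular change does, so the expectation must stay cautious. For compound 4 a small upward move from the number of compound 2 is expected, a 2.6-fold higher number from compound 2 to compound 4 (0.42 log units; beyond the scatter), which may well stay inside the scatter. Compound 4 is therefore estimated at 250 nM in this assay, with a plausible range from 80 nM to 800 nM.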

Compound 4, half-maximal effective concentration: 435 nM
Estimate against measurement, compound 4: 1.7-fold (0.24 log units) below; low and high end bracket the measured number.
By their numbers in this assay, from the lowest: compound 2; then compounds 4 and 3 (each within the scatter of the next); then compound 1.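

In this assay, going by these compounds alone, this pair gives the first single-point reading at this position, and the step is a 4.5-fold higher number from compound 2 to compound 4 (0.66 log units; beyond the scatter) and so lies beyond the scatter. Cyclohexyl and oxan-4-yl have the same number of heavy atoms, yet replacing one ring carbon with oxygen, which adds one hydrogen-bond acceptor to the count, goes with a higher number, so the position responds even to an exchange this small. Nothing available explains why the number moves in this direction.

This single pair cannot show whether any ring atom other than carbon would raise the number, or whether oxygen specifically matters. Open too, from the compounds shown here alone, is how a piperidin-4-yl group with its ring nitrogen, or a smaller cyclopentyl ring, would read at the same position.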